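The source may report more compounds than this note shows. Statements on the series, on what has been measured and on what is new or still open speak of the compounds shown alone.

Of the compounds shown here, three of one series have been measured in a physicochemical assay for lipophilicity; a lower number here means a more polar compound, a higher number a more lipophilic compound. Compound 1 `CCCOc1ccc2[nH]c(-c3ccccc3)c(C3=C(Br)C(=O)NC3=O)c2c1` gives 3.16. Compound 2 `CCCCOc1ccc2[nH]c(-c3ccccc3)c(C3=C(Br)C(=O)NC3=O)c2c1` gives 3.42. Compound 3 `COc1ccc(-c2[nH]c3c(C)cccc3c2C2=C(Br)C(=O)NC2=O)cc1` gives 3.12. Compound 4 `CCc1cccc2c(C3=C(Br)C(=O)NC3=O)c(-c3ccc(OC)cc3)[nH]c12` has not yet been measured in this assay.

The change from compound 1 to compound 2 is methyl in place of hydrogen on a saturated chain carbon, three bonds along the chain from an oxygen on an aromatic ring. It made a step of a number 0.26 log units higher from compound 1 to compound 2 (within the scatter).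

Compound 4 differs from compound 3 by methyl in place of hydrogen on a saturated chain carbon bound to an aromatic carbon. For the measured compounds named here, this is the same kind of change as the one from compound 1 to compound 2, made on a different core: the difference between the core of compound 1 and the core of compound 3 is not broken down here. The place also differs: in compound 2 the new methyl stands on a saturated chain carbon, three bonds along the chain from an oxygen on an aromatic ring, whereas in compound 4 it stands on a saturated chain carbon bound to an aromatic carbon.

For compound 4 a step of a number 0.30 log units higher from compound 3 to compound 4 (within the scatter) is expected, resting on compound 1 and compound 2, whose step was a number 0.26 log units higher from compound 1 to compound 2 (within the scatter). Compound 4 is therefore estimated at 3.42, between 3.15 and 3.7.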

Compound 4, partition coefficient: 3.35
Beside the measured number, compound 4's estimate is 0.07 log units above it, and the stated range covers the measured number.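

The new step in this assay is a number 0.23 log units higher from compound 3 to compound 4 (within the scatter), and it stands with the earlier step on the other core, a number 0.26 log units higher from compound 1 to compound 2 (within the scatter), so in both pairs the same kind of change, methyl in place of hydrogen, gives a step of similar size. Both steps lie within the scatter, however, so neither can be told apart from what repeated measurement of a single compound might give, and two such pairs, with the methyl in different places, do not show that this change carries a fixed size from one core to another. Nothing shown here offers a reason for the size of either step.

On these data alone, whether a longer chain such as propyl, an amine or a carboxylic acid on the same saturated chain carbon bound to an aromatic carbon would give a step beyond the scatter stays open. So does whether the methyl change would keep its size on a further core.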